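A few compounds are considered here, and "the series" means these few. Any claim that something is new, unique, unknown or untested is made for them only; others in the source may bear on it.

Of the compounds shown here, two built on a shared core have been measured in an assay on isolated protein for displacement of a labelled ligand from metabotropic glutamate receptor 5 (Homo sapiens), with a stated time of 60 min, tested at 1 uM; a lower number here means less inhibition, a higher number more inhibition at the concentration tested (going by the name of the read-out). Compound 1 `COc1ccc(S(=O)(=O)c2cnc3ccc(C)cc3c2N2CCC(C)CC2)cc1Cl` gives 93%. Compound 2 `CC1CCN(c2c(S(=O)(=O)c3cc(Cl)cc(Cl)c3)cnc3ccc(Cl)cc23)CC1` gives 88%. Compound 2 thus has the lower of the two numbers, but its gap to compound 1 lies within the usual scatter of repeated measurements, so the two values cannot be told apart with confidence.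

Compound 3 `CC1CCN(c2c(S(=O)(=O)c3cc(Cl)cc(Cl)c3)cnc3ccc(F)cc23)CC1` has not yet been measured in this assay. It differs from compound 2 in a single place: fluoro in place of chloro on an aromatic carbon. The fluoro takes the position of the chloro on the aromatic carbon of the six-membered carbon-only ring within the fused two-ring system.

Among the compounds with values here, no pair of measured compounds differing in one place exists here, so there is no comparable step to lean on. Because compound 2 already gives 88%, there is little room upward, and for this exchange a step no larger than the scatter is expected, if anything pointing downward. The expected step of a number 6 percentage points lower from compound 2 to compound 3 (within the scatter) reflects this. Compound 3 is expected to give 82%, with a likely range from 62% to 96%.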

Compound 3, a percentage reported as inhibition, at one concentration (the size of the read-out at that concentration, not a potency): 69%
Compound 3: middle estimate off by 13 percentage points, on the high side; the range from low to high includes it.
By their numbers in this assay, from the lowest: compound 3; then compounds 2 and 1 (each within the scatter of the next).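

In this assay, exchanging chloro for fluoro on an aromatic carbon of the six-membered carbon-only ring comes with a number 19 percentage points lower from compound 2 to compound 3 (beyond the scatter), so the group at this position does affect the read-out, and even an exchange of one halogen for another, with one heavy atom leaving and one entering, can be enough to show it. Within the data shown here, compounds 1 and 2 differ in more than one place, so they could not isolate any single change, whereas this pair gives a first reading for one position, though only as inhibition at one concentration and not as a potency. Nothing measured here explains why this exchange lowers the number.

The compounds shown leave open how bromo, trifluoromethyl or a nitrile on this same aromatic carbon would compare with chloro and fluoro, so a single step cannot yet define a trend at this position. On these data alone, it also remains open whether the exchange of chloro for fluoro would give a step of similar size with a different group on the sulfonyl or in place of the 4-methylpiperidine.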